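The source may report more compounds than this note shows. Statements on the series, on what has been measured and on what is new or still open speak of the compounds shown alone.

Working notes, compound 3 to compound 4. Compound 3 `Cc1noc(-c2nc(C)c3c(c2N)C(=O)N(Cc2ccc(-n4cccn4)cc2)C3=O)n1` has been run in a physicochemical assay for solubility, using the shake flask method, in simulated intestinal fluid, measured as kinetic solubility, with a stated time of 2 h, at 25 degrees C, at pH 6.5; a higher number here means a more soluble compound, a lower number a less soluble compound. For compound 3 the result is a limit of the assay, not a number: < 5000 nM. Compound 1 `Cc1nnc(-c2nc(C)c3c(c2N)C(=O)N(Cc2ccccc2)C3=O)o1` sits at the same limit, with < 5000 nM. Only compound 2 `Cc1nc(C(=O)NC#N)c(N)c2c1C(=O)N(Cc1ccccc1)C2=O` returns a number, giving 185000 nM in this assay. Compound 3 therefore stands at the limit of < 5000 nM in this assay, at which 2 of the 3 values shown sit, together with compound 1, and only compound 2 lies clear of that limit.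

Compound 4 `Cc1noc(-c2nc(C)c3c(c2N)C(=O)N(Cc2ccc(C(N)=O)cc2)C3=O)n1` differs from compound 3 in one place: carbamoyl in place of 1H-pyrazol-1-yl on an aromatic carbon. The change sits on an aromatic carbon of a six-membered aromatic ring of carbon only, para to a large group.

Within the data shown here, the single measured step, an at least 37-fold higher number from compound 1 to compound 2 (1.56 log units; beyond the scatter), concerns a different place on the shared core and a different pair of groups, so it bears on the present change only by showing that one exchange on this core can move the read-out a long way. Among the measured compounds shown here, no measured step covers the place changed here, and the value of compound 3 is only a limit, so the size of the step from compound 3 to compound 4 is uncertain.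

On that basis compound 4 is expected to give 12000 nM in this assay, estimated within 3000 nM to 50000 nM. The expected step of an at least 2.4-fold higher number from compound 3 to compound 4 (0.38 log units; beyond the scatter) is an estimate that may still end at the limit.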

Compound 4, solubility: < 5000 nM
Compound 4 ended at the assay's limit; the forecaster's own chance of this, stated with the estimate: 40%; at least 2.4-fold (0.38 log units) between middle value and limit.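

Compound 4 gives < 5000 nM in this assay and that value is a limit of the assay, not a number. Compound 3 also sits at a limit, and the step from compound 3 to compound 4 cannot be read: the limit of < 5000 nM in this assay, at which 3 of the 4 values shown sit.

The compounds shown leave open whether carbamoyl or 1H-pyrazol-1-yl at this place gives the higher number.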